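The compounds below may be only part of what the source reports. "The series", "measured", "known", "first", "only" and "open" are said of these compounds alone.

In a functional assay on KB cells (Homo sapiens) for inhibition, read by MTT assay, with a stated time of 24 h, tested at 10 ug/mL (on this read-out lower numbers stand for less inhibition of growth and higher numbers for more inhibition of growth at the one concentration tested), compound 3 (`O=C(CCCCC(S)CCS)Nc1ccc(Cl)cn1`) reads 21.6% and stands second highest of the three numbers in hand. Compound 1 (`O=C(CCCCC1CCSS1)Nc1ccc(Br)cn1`) stands higher and reads 35.1%, and compound 2 (`O=C(CCCCC(S)CCS)Nc1ccccn1`) stands lower and reads 0.28% so far. Next comes compound 4 (`O=C(CCCCC(S)CCS)Nc1ccc(Br)cn1`), with bromo in place of chloro on an aromatic carbon as the change, that is, bromo in place of chloro on an aromatic carbon. Going by the values given here, the one measured step at this place is a number 21.3 percentage points higher from compound 2 to compound 3 (beyond the scatter) for chloro in place of hydrogen, a modest move. Among the compounds with values here, no measured step exchanges chloro for bromo directly. Compound 1 carries bromo at the same place on a different chain, and its reading of 35.1% gives only a loose upward hint. A small upward move is therefore expected, with nothing beyond the scatter. The estimated step is a number 3.4 percentage points higher from compound 3 to compound 4 (within the scatter) and stays within the usual scatter. Compound 4 is estimated at 25% with 12% to 40% as the expected range.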

Compound 4, percent growth inhibition at one concentration: 34.1%
Compound 4: middle estimate off by 9.1 percentage points, on the low side; measured number inside the range.
By their numbers in this assay, from the lowest: compound 2; then compound 3; then compounds 4 and 1 (each within the scatter of the next).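

In this assay the identity of the halogen at this place counts: bromo in place of chloro gives a number 12.5 percentage points higher from compound 3 to compound 4 (beyond the scatter) and so separates the two halogens, which the earlier step of a number 21.3 percentage points higher from compound 2 to compound 3 (beyond the scatter) alone could not show. Bromo in place of hydrogen gives a number 33.8 percentage points higher from compound 2 to compound 4 (beyond the scatter) and is the largest step at this place among the compounds shown. With bromo held fixed, the ring-free group of 5 heavy atoms in place of the five-membered non-aromatic ring gives a number 1 percentage points lower from compound 1 to compound 4 (within the scatter) and leaves the two chain forms undistinguished at the one concentration tested. Nothing in hand bears on why bromo and chloro differ here.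

Open, from the compounds shown here alone, is whether the rise from hydrogen through chloro to bromo extends to iodo, or whether a methoxy group or an amine at this place fits it. Also open, going by these compounds, is whether the two chain forms stay level with chloro or hydrogen on the ring, since only the bromo pair compares them.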